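This account rests on a few compounds, and the source may have more. Where it says the series, first, only, none or still open, it means among the compounds named here.

Going by the values given here, compound 1 `Nc1ncnc2c1ncn2C[C@@H]1C[C@H](CO)c2ccccc21` stands as the higher of the two numbers so far: in a functional assay on CCRF-CEM cells (Homo sapiens) (a lower number here means a stronger inhibitor, a higher number a weaker inhibitor), compound 1 gives 24 ug/mL, while compound 2 `Cn1ncc2c1[C@H](Cn1cnc3c(Cl)ncnc31)C[C@@H]2CO[Si](c1ccccc1)(c1ccccc1)C(C)(C)C` gives 3.2 ug/mL, a gap beyond the usual scatter. Compound 3 `OC[C@H]1C[C@@H](Cn2cnc3c(-c4ccc(Cl)cc4)ncnc32)c2ccccc21` differs from compound 1 by 4-chlorophenyl in place of amino on an aromatic carbon. Among the compounds with values here, no measured pair shows this exact change, so the direction rests only on the wider set. Within the data shown here, a moderate step toward a lower number is expected, a 2.4-fold lower number from compound 1 to compound 3 (0.38 log units; beyond the scatter), since the only other compound, compound 2, sits at 3.2 ug/mL. Compound 3 is estimated at 10 ug/mL, with a range from 2.5 ug/mL to 40 ug/mL.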

Compound 3, half-maximal inhibitory concentration: 0.63 ug/mL
Compound 3: middle estimate off by 16-fold (1.20 log units), on the high side, outside the stated range (below it).
By their numbers in this assay, from the lowest: compound 3; then compound 2; then compound 1.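

Going by these compounds alone, on this aromatic carbon of the shared core, 4-chlorophenyl in place of amino gives a 38-fold lower number from compound 1 to compound 3 (1.58 log units; beyond the scatter) in this assay, the first single-place step. Amino is therefore not required here for activity, and a much larger aromatic group is accepted, with the number falling rather than rising. Nothing measured bears on the reason for this step.

On these data alone, it remains open whether the step comes from the aromatic ring or from its chlorine. Phenyl without chlorine, 4-methoxyphenyl or a dimethylamino group at this carbon would separate these readings.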